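This account rests on a few compounds, and the source may have more. Where it says the series, first, only, none or still open, it means among the compounds named here.

Measured compounds:
compound 1 `CC(=O)N1N=C(c2ccc(N3CCN(C)CC3)cc2)CC1c1ccc(N(C)C)cc1`: -0.8%
compound 2 `Cc1ccc(C(=O)N2N=C(c3ccc(N4CCN(C)CC4)cc3)CC2c2ccc(N(C)C)cc2)cc1`: -2.5%
compound 3 `C=C(C)C(=O)N1N=C(c2ccc(-n3ccnc3)cc2)CC1c1ccc(N(C)C)cc1`: 1.6%

In a functional assay on HCC1806 cells (Homo sapiens) for inhibition, read by sulforhodamine B assay, tested at 10 uM (a higher number here means more inhibition at the concentration tested (going by the name of the read-out), a lower number less inhibition), compound 3 gives 1.6%. Compound 1 gives -0.8% and compound 2 gives -2.5%, and both of these numbers lie within the usual scatter of the value of compound 3, so no order among the three can be read from them. For the measured compounds named here, the one measured step, a number 1.7 percentage points lower from compound 1 to compound 2 (within the scatter), replaces methyl on the carbonyl carbon with 4-methylphenyl and stays within the scatter.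

Compound 4 `CN(C)c1ccc(C2CC(c3ccc(-n4ccnc4)cc3)=NN2S(=O)(=O)c2ccc([N+](=O)[O-])cc2)cc1` differs from compound 3 as follows: (4-nitrophenyl)sulfonyl in place of (1-methylethenyl)carbonyl on an amine nitrogen in a ring. Going by the values given here, no measured pair changes the group on that ring nitrogen from a carbonyl-bearing group to a sulfonyl-bearing one, so the only step that touches this position, from compound 1 to compound 2, is a loose guide, and it showed no change beyond the scatter. Compound 4 is therefore expected to give 2% in this assay, in a range from -9% to 16%. The expected step is a number 0.4 percentage points higher from compound 3 to compound 4 (within the scatter), which would lie within the scatter.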

Compound 4, a percentage reported as inhibition, at one concentration (the size of the read-out at that concentration, not a potency): 46.6%
Compound 4: the middle estimate sits 44.6 percentage points below what was measured, and the stated range ends below it.
By their numbers in this assay, from the lowest: compounds 2, 1 and 3 (each within the scatter of the next); then compound 4.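

In this assay, the group on the ring nitrogen turns out to matter: a number 45 percentage points higher from compound 3 to compound 4 (beyond the scatter), the first step among these compounds to pass beyond the scatter. The earlier step at this nitrogen, a number 1.7 percentage points lower from compound 1 to compound 2 (within the scatter), swapped one carbonyl-bearing group for another, whereas here (4-nitrophenyl)sulfonyl replaces (1-methylethenyl)carbonyl, so a sulfonyl-bearing group on this nitrogen is compatible with a far larger read-out than any of the carbonyl-bearing groups shown. Nothing available here accounts for the rise.

The sulfonyl link, the aromatic ring and the nitro group all enter in this single step, so the compounds shown leave open which of them carries it. A 4-nitrobenzoyl group, a phenylsulfonyl group without the nitro group or a 4-aminophenylsulfonyl group on the same nitrogen would separate these parts.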